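The source may report more compounds than this note shows. Statements on the series, on what has been measured and on what is new or still open speak of the compounds shown alone.

Working notes on the urea series. Among the compounds with values here, compound 1 `Cc1cc(C)c(NC(=O)N(Cc2cccc(-c3nnnn3C)c2)C2CCCCCC2)c(C)c1` and compound 2 `CSc1cc(C)nc(SC)c1NC(=O)N(Cc1ccccc1)Cc1cccc(-c2ccnn2C)c1` are the two compounds measured so far in a functional assay on a cell-free system (plasma) with sterol O-acyltransferase, Soat (Rattus norvegicus) as the target; on this read-out higher numbers stand for an effect only at larger amounts of compound and lower numbers for an effect already at smaller amounts. In this assay compound 1 gives > 1 mg/kg, which is a limit of the assay and not a number (the limit of > 1 mg/kg in this assay, at which 1 of the 2 values shown sits). In this assay compound 2 gives < 1 mg/kg, again a limit rather than a number (the limit of < 1 mg/kg in this assay, at which 1 of the 2 values shown sits). The two compounds differ in several places at once, so their values show only that one sits at each limit; no single step can be read from them, and where compound 1 stands is known only as a limit.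

Compound 3 `Cc1cc(C)c(NC(=O)N(Cc2cccc(-c3cnn(C)c3)c2)C2CCCCCC2)c(C)c1` is the next compound to be measured. It differs from compound 1 by 1-methyl-1H-pyrazol-4-yl in place of 1-methyl-1H-tetrazol-5-yl on an aromatic carbon. Within the data shown here, no measured step covers this change; the expected step is a step that the limit leaves unreadable from compound 1 to compound 3, small and not clearly beyond the usual scatter. Compound 3 is expected to give 2 mg/kg in this assay, with a range from 0.5 mg/kg to 8 mg/kg.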

Compound 3, dose for half-maximal effect: < 1 mg/kg
Compound 3: only a limit was reported (the forecaster's own chance of this, stated with the estimate: 40%); middle value at least 2.0-fold (0.30 log units) away from the limit.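

Within the data shown here, with the rest of compound 1 held fixed, this is the first single change that can be read in this assay: 1-methyl-1H-pyrazol-4-yl in place of 1-methyl-1H-tetrazol-5-yl on an aromatic carbon, meta to a large group, gives a number no higher from compound 1 to compound 3 (the limit leaves the size open). Among these compounds, the direction shows that this position accepts the five-membered aromatic ring with 2 hetero atoms without any loss of effect, which the earlier compounds, differing in several places at once, could not show. Compound 3 gives a limit and not a number: the limit of < 1 mg/kg in this assay, at which 2 of the 3 values shown sit.

How large the step is cannot be read, nor which difference between the two rings counts, the hetero atoms or the hydrogen-bond acceptors. Going by these compounds, whether an open-chain group at this place, such as an amine or a carboxylic acid, would keep the effect in this assay also stays open.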